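Swapping a methylphenyl for a fluorophenyl on sulfur

This account rests on a few compounds, and the source may have more. Where it says the series, first, only, none or still open, it means among the compounds named here.

Of the compounds shown here, three have been tested in a functional assay on A-375 cells (Homo sapiens) for inhibition, read by CCK-8 assay, with a stated time of 72 h, tested at 2 uM; on this read-out higher numbers stand for more inhibition of growth at the one concentration tested and lower numbers for less inhibition of growth. Compound 1 `Cc1ccc(SCc2ccc(/C=C/C(=O)Nc3ccccc3N)cc2)cc1` gives 22.9% in this assay. Compound 2 `Nc1ccccc1NC(=O)c1ccc(CSc2nccc(C(F)(F)F)n2)cc1` gives 54.4%, and compound 3 `Nc1ccccc1NC(=O)c1ccc(CSc2ccc(Br)cc2)cc1` gives 4.35%. Among these three numbers compound 1 stands second highest: compound 3 lies below it by a margin beyond the usual scatter of repeat measurements, and compound 2 lies above it by a larger margin, also beyond the scatter. Compound 2 and compound 3 each differ from compound 1 in more than one place, so none of these gaps can be pinned on a single structural change.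

The next compound, compound 4 `Nc1ccccc1NC(=O)/C=C/c1ccc(CSc2cccc(F)c2)cc1`, keeps the whole of compound 1 except at one point: 3-fluorophenyl in place of 4-methylphenyl on a sulfur. Going by the values given here, no pair of measured compounds shows this particular exchange, so there is no measured step to lean on. The rest of the molecule is unchanged and the entering group matches the leaving group in heavy-atom count and ring count. On that basis the step in this assay is expected to be a number 0.9 percentage points lower from compound 1 to compound 4 (within the scatter), that is, small and within the usual scatter. Compound 4 is therefore expected to give about 22% in this assay, with a plausible range from 6% to 40%.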

Compound 4, percent growth inhibition at one concentration: 6.75%
Beside the measured number, compound 4's estimate is 15.3 percentage points above it; measured number inside the range.
By their numbers in this assay, from the lowest: compounds 3 and 4 (each within the scatter of the next); then compound 1; then compound 2.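

Going by these compounds alone, this is the first exchange that can be read at a single place: in this assay, the group on the sulfur is not a silent position, since 3-fluorophenyl in place of 4-methylphenyl gives a number 16.2 percentage points lower from compound 1 to compound 4 (beyond the scatter). The two groups have the same heavy-atom count, the same single six-membered aromatic ring of carbon only, and no hydrogen-bond donors or acceptors, so these counts alone do not settle the number here; the identity of the group on the sulfur matters even when those counts stay the same. No measurement is available to say why this exchange lowers the number.

Within the data shown here, the single step changes two things at once, the kind of substituent on the ring (methyl or fluorine) and where it sits, so a compound carrying 4-fluorophenyl or 3-methylphenyl on the sulfur would be needed to tell these apart. On these data alone, it also remains open whether the same exchange would give a step of similar size on the core of compound 3, or how a larger ring substituent such as a methoxy group or an amine would behave at this position.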